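Removing the hydroxy group from compound 1

The compounds below may be only part of what the source reports. "The series", "measured", "known", "first", "only" and "open" are said of these compounds alone.

Measured in an ADME assay on a cell-free system (plasma, Homo sapiens) for protein binding; on this read-out higher numbers stand for a larger free fraction and lower numbers for a smaller free fraction:
Compound 1 `Cc1cc(C(=O)N[C@H]2CC[C@@H](NC(=O)c3cc(F)cnc3Oc3cccc(-c4cccc(CN5C[C@@H](C)N[C@@H](C)C5)c4O)c3)CC2)nn1C`: 0.091
Compound 2 `Cc1cc(C(=O)N[C@H]2CC[C@@H](NC(=O)c3cc(F)cnc3Oc3cccc(-c4ccc(CN5C[C@@H](C)N[C@@H](C)C5)cc4)c3)CC2)nn1C`: 0.11
Compound 3 `Cc1cc(C(=O)N[C@H]2CC[C@@H](NC(=O)c3cc(F)cnc3Oc3cccc(-c4ccc(CCCN5C[C@@H](C)N[C@@H](C)C5)cc4)c3)CC2)nn1C`: 0.045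

Compound 1, at 0.091, lies within the scatter of compound 2, while compound 3 has the lowest number of the three at 0.045. The next compound to be measured is compound 4 `Cc1cc(C(=O)N[C@H]2CC[C@@H](NC(=O)c3cc(F)cnc3Oc3cccc(-c4cccc(CN5C[C@@H](C)N[C@@H](C)C5)c4)c3)CC2)nn1C`, and its change from compound 1 is hydrogen in place of hydroxy on an aromatic carbon. In words, hydrogen stands in place of hydroxy on an aromatic carbon.

Among the measured compounds shown here, the only measured step in one place, a 2.4-fold lower number from compound 2 to compound 3 (0.39 log units; beyond the scatter), is modest, but it concerns the group carrying the 3,5-dimethylpiperazin-1-yl and leaves the hydroxy question untouched. Compound 2 also has no hydroxy and gives 0.11, although it differs from compound 1 in more than that. For the measured compounds named here, no measured pair isolates this change, so no step beyond the scatter is expected in this assay.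

The expected change is a 1.0-fold lower number from compound 1 to compound 4 (0.00 log units; within the scatter). Compound 4 is estimated at 0.09, with an expected range from 0.055 to 0.15.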

Compound 4, unbound fraction in the plasma assay: 0.18
The estimate for compound 4 lay 2.0-fold (0.30 log units) below the measured number; measured number above the stated range.
By their numbers in the plasma assay, from the lowest: compound 3; then compounds 1, 2 and 4 (each within the scatter of the next).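

Placing hydrogen in place of hydroxy on this aromatic carbon, ortho to a (3,5-dimethylpiperazin-1-yl)methyl group, gives in the plasma assay a 2.0-fold higher number from compound 1 to compound 4 (0.30 log units; within the scatter), so this pair, the first to isolate the change, shows no step that can be read beyond the scatter. In a physicochemical assay for lipophilicity (a higher number here means a more lipophilic compound, a lower number a more polar compound), the same change gives a number 0.70 log units lower from compound 1 to compound 4 (beyond the scatter), so it registers clearly on that read-out even though the free fraction does not separate the two compounds. In the physicochemical assay compound 1 gives 2.8 and compound 4 gives 2.1. The pair thus shows that at this position the compound without the hydroxy is measurably the more polar one: the measured distribution coefficient of compound 1, 2.8, and of compound 4, 2.1, a number 0.70 log units lower (beyond the scatter)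

The compounds shown leave open whether a methoxy group, a fluorine atom or an amine on this aromatic carbon would shift the free fraction beyond the scatter. They also leave open whether hydrogen in place of hydroxy would read the same way in a compound carrying the 2-(3,5-dimethylpiperazin-1-yl)ethyl group.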